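From Oxadiazole to Thiazole on a Shared Core

The source may hold more compounds than are shown below. What is called first, only, known or untested is meant among the compounds shown, and "the series" means these compounds.

In a physicochemical assay for solubility, measured as kinetic solubility, at pH 2 (a lower number here means a less soluble compound, a higher number a more soluble compound), compound 1 (`CN(C)c1noc(-c2cccc(CN(C)c3ccc4[nH]nc(C(=O)O)c4c3)c2O)n1`) stands highest of the two measured compounds at 16000 nM, while compound 2 (`Cc1csc(-c2cccc(CNc3ccc4[nH]nc(C(=O)O)c4c3)c2O)n1`) gives 5000 nM. The gap between these two values lies beyond the scatter. Compound 3 (`CC(C)c1csc(-c2cccc(CN(C)c3ccc4[nH]nc(C(=O)O)c4c3)c2O)n1`) carries 4-isopropyl-1,3-thiazol-2-yl in place of the 3-(dimethylamino)-1,2,4-oxadiazol-5-yl of compound 1 (4-isopropyl-1,3-thiazol-2-yl in place of 3-(dimethylamino)-1,2,4-oxadiazol-5-yl on an aromatic carbon). For the measured compounds named here, no measured step isolates this change. Compound 2, at 5000 nM, also carries a thiazole, so a lower number is expected in this assay. The expected change is a 6.4-fold lower number from compound 1 to compound 3 (0.81 log units; beyond the scatter). For compound 3 the estimated value is 2500 nM, within an expected range of 600 nM to 8000 nM.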

Compound 3, solubility: 175000 nM
Compound 3: middle estimate off by 70-fold (1.85 log units), on the low side; the measured number lies above the stated range.
By their numbers in this assay, from the lowest: compound 2; then compound 1; then compound 3.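

Swapping 3-(dimethylamino)-1,2,4-oxadiazol-5-yl for 4-isopropyl-1,3-thiazol-2-yl, on an aromatic carbon ortho to a hydroxy group, gives an 11-fold higher number from compound 1 to compound 3 (1.04 log units; beyond the scatter) in this assay, a large step beyond the scatter. It is the first single-place change shown, and it reveals that this position alone can move the number strongly upward, even though the entering and leaving groups have the same heavy-atom count. No evidence on hand accounts for the size of this step.

From the compounds shown here alone, it remains open whether the ring or its substituent carries the step. An oxadiazole bearing isopropyl, or a thiazole bearing dimethylamino, at this position would separate the two.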